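The source may hold more compounds than are shown below. What is called first, only, known or untested is meant among the compounds shown, and "the series" means these compounds.

Measured so far:
- Compound 1, `Cc1nc(-c2ccccc2)c(C(=O)N2CCN(c3c(C)cccc3C)CC2)o1`: 146 nM
- Compound 2, `Cc1ccc(C)c(N2CCN(C(=O)c3oc(C)nc3-c3ccc(Cl)cc3)CC2)c1`: "not active" (no number reported)
- Compound 3, `CCCc1nc(-c2ccc(OC)cc2)c(C(=O)N2CCN(c3cccc(Cl)c3)CC2)o1`: "not active" (no number reported)

The three compounds share a core and were tested in a functional assay on HL-60 cells (Homo sapiens) for inhibition, read by MTT assay, with a stated time of 72 h; on this read-out lower numbers stand for stronger inhibition and higher numbers for weaker inhibition. Among the measured compounds shown here, compound 1 is the only one for which a number is reported, giving 146 nM. For compound 2 and compound 3 no number is reported, only that each was found not active, so no ordering among the three can be drawn beyond compound 1 standing alone with a measured value.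

Compound 4, `Cc1cc(C)cc(N2CCN(C(=O)c3oc(C)nc3-c3ccccc3)CC2)c1`, has not yet been measured. It differs from compound 1 in one place, (3,5-dimethylphenyl in place of 2,6-dimethylphenyl on an amine nitrogen in a ring), and the two contain the same atoms joined differently. For the measured compounds named here, since no measured pair shows the effect of such a change, and the two further entries give no number to compare with, the step from compound 1 is expected to be modest and toward weaker inhibition, with wide uncertainty, as a 2.7-fold higher number from compound 1 to compound 4 (0.44 log units; beyond the scatter). Compound 4 is therefore estimated at 400 nM, in a range from 100 nM to 3000 nM.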

Compound 4, half-maximal inhibitory concentration: 34.5 nM
Estimate against measurement, compound 4: 12-fold (1.06 log units) above; measured number outside the range, below it.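

In this assay, putting 3,5-dimethylphenyl in place of 2,6-dimethylphenyl on the amine nitrogen in the ring gives a 4.2-fold lower number from compound 1 to compound 4 (0.63 log units; beyond the scatter) and the atoms stay the same, joined differently. Among the compounds shown here, this matched pair is the first to show that this position responds to where the two methyl groups sit on the phenyl ring, and not only to which atoms are present. Nothing measured here says why the arrangement matters.

Going by these compounds, it remains open whether the stronger inhibition needs methyl groups at all, or would also appear with another group in the same arrangement, such as 3,5-dimethoxyphenyl or 3,5-dichlorophenyl. Compound 2 and compound 3 have no number and differ from compound 4 in more than one place, so they cannot settle this.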